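From 2-hydroxyphenyl to 4-chlorophenyl: working notes

A few compounds are considered here, and "the series" means these few. Any claim that something is new, unique, unknown or untested is made for them only; others in the source may bear on it.

In a functional assay on A549 cells (Homo sapiens) for antiproliferative activity, read by MTT assay, with a stated time of 72 h (a higher number here means a weaker inhibitor, a lower number a stronger inhibitor), compound 1 (`Cc1nc(C)c(/C=C/C(=O)/C=C/c2ccccc2O)nc1C`) gives 4780 nM, and compound 2 (`COc1ccccc1/C=C/C(=O)/C=C/c1nc(C)c(C)nc1C`) gives 3200 nM. Compound 1 therefore has one measured neighbour, and the two values lie within the scatter of each other.

Compound 3 (`Cc1nc(C)c(/C=C/C(=O)/C=C/c2ccc(Cl)cc2)nc1C`) carries 4-chlorophenyl in place of 2-hydroxyphenyl on a double-bonded chain carbon bound to a double-bonded chain carbon.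

Among the compounds with values here, only one measured step bears on this change: a 1.5-fold lower number from compound 1 to compound 2 (0.17 log units; within the scatter), with methyl in place of hydrogen on an oxygen on an aromatic ring. Within the data shown here, it is a small step, but it is only a partial guide, since no measured compound carries chlorine. No step beyond the scatter is therefore expected in this assay, and any direction is tentative.

The expected step is a 1.4-fold lower number from compound 1 to compound 3 (0.14 log units; within the scatter).

For compound 3 the estimate is 3500 nM, with an expected range of 1200 nM to 9000 nM.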

Compound 3, half-maximal inhibitory concentration: 15800 nM
For compound 3 the middle estimate is 4.5-fold (0.65 log units) below the measured one, outside the stated range (above it).
By their numbers in this assay, from the lowest: compounds 2 and 1 (each within the scatter of the next); then compound 3.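

In this assay, within the data shown here, 4-chlorophenyl in place of 2-hydroxyphenyl on a double-bonded chain carbon bound to a double-bonded chain carbon gives a 3.3-fold higher number from compound 1 to compound 3 (0.52 log units; beyond the scatter), the first step that lies beyond the scatter. Among these compounds, the only earlier step, a 1.5-fold lower number from compound 1 to compound 2 (0.17 log units; within the scatter), changed just the hydrogen on the oxygen, so the series now shows that the number can respond to a change of the whole aryl group at this position, even though the heavy-atom count stays the same. No measurement at hand accounts for this step.

The change removes the oxygen and brings in chlorine at once, so the two contributions remain unseparated. An unsubstituted phenyl, a 2-chlorophenyl or a 4-hydroxyphenyl at this position would divide the step, and an aminophenyl remains an open case as well.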